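A few compounds are considered here, and "the series" means these few. Any claim that something is new, unique, unknown or untested is made for them only; others in the source may bear on it.

Compound 1 `Nc1cccc(-c2cn3nc(-c4ccc(F)cc4)sc3n2)c1`: in a functional assay on L1210 cells (Mus musculus) for inhibition, read by cell counting, with a stated time of 2 days (on this read-out higher numbers stand for weaker inhibition and lower numbers for stronger inhibition), compound 1 gives >= 250000 nM, which is a limit of the assay rather than a number.
Compound 2 `Nc1cccc(-c2cn3nc(-c4ccc(Cl)cc4)sc3n2)c1`: in this assay compound 2 gives >= 250000 nM, likewise only a limit.
Compound 3 `Nc1cccc(-c2cn3nc(-c4ccccc4)sc3n2)c1`: in this assay compound 3 gives 32000 nM.

Going by the values given here, compound 3 therefore stands as the one compound with a real number, while the other two sit at the limit of >= 250000 nM in this assay, at which 2 of the 3 values shown sit. Compound 4 `Cc1ccc(-c2nn3cc(-c4cccc(N)c4)nc3s2)cc1` differs from compound 3 by methyl in place of hydrogen on an aromatic carbon. Both measured steps bear on a group at this place: an at least 7.8-fold lower number from compound 1 to compound 3 (0.89 log units; beyond the scatter) and an at least 7.8-fold lower number from compound 2 to compound 3 (0.89 log units; beyond the scatter) each show that taking a group away there lowered the number at least modestly, while a step that the two limits leave unreadable from compound 1 to compound 2 says nothing usable. Putting a group back is thus expected to raise the number, possibly up to the limit. For compound 4 the expected value is 150000 nM, within 40000 nM to 300000 nM, meaning an expected 4.7-fold higher number from compound 3 to compound 4 (0.67 log units; beyond the scatter).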

Compound 4, half-maximal inhibitory concentration: 4800 nM
For compound 4 the middle estimate is 31-fold (1.49 log units) above the measured one, and the stated range ends above it.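

Going from phenyl to 4-methylphenyl gives a 6.7-fold lower number from compound 3 to compound 4 (0.82 log units; beyond the scatter), so a group at this place does not have to raise the number. What matters is which group sits there: methyl in place of chloro gives an at least 52-fold lower number from compound 2 to compound 4 (1.71 log units; beyond the scatter), and methyl in place of fluoro gives an at least 52-fold lower number from compound 1 to compound 4 (1.71 log units; beyond the scatter). Compound 1 and compound 2 rest on a limit rather than a number, so the full size of these two steps stays unknown: the limit of >= 250000 nM in this assay, at which 2 of the 4 values shown sit.

The compounds shown leave open whether an ethyl, a methoxy or a trifluoromethyl group at this place would behave like methyl or like fluoro and chloro.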